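An Ethyl Group Replaces the Methylcarbamoyl Group

This account rests on a few compounds, and the source may have more. Where it says the series, first, only, none or still open, it means among the compounds named here.

Of the compounds shown here, three with a shared core have been tested in a functional assay on the whole organism with Canis familiaris (Canis lupus familiaris) as the target, at a dose of 5 mg/kg by the intravenous route; on this read-out higher numbers stand for a stronger effect at the one dose given and lower numbers for a weaker effect. Compound 1 `Cc1ccn2c(N)c(C)nc2c1OCc1ccccc1` gives 55%, and compound 2 `Cc1nc2c(OCc3ccccc3)cccn2c1CN` gives 49% in this assay. Compound 3 `CNC(=O)Nc1c(C)nc2c(OCc3ccccc3)cccn12` gives 27%, the lowest of the three numbers, and the step of a number 22 percentage points lower from compound 2 to compound 3 (beyond the scatter) lies beyond the scatter. Compound 4 `CCNc1c(C)nc2c(OCc3ccccc3)cccn12` differs from compound 3 by ethyl in place of methylcarbamoyl on a nitrogen on an aromatic ring. Going by the values given here, no measured step matches this change; the only known step concerns a different substituent. Since compounds 1 and 2, which lack the methylcarbamoyl group, both give numbers near half, an upward step is expected, though with wide uncertainty. Compound 4 is therefore expected to give 40%, with a range from 20% to 60%. The expected step is a number 13 percentage points higher from compound 3 to compound 4 (beyond the scatter).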

Compound 4, a percentage reported as inhibition, in the whole organism at one dose (the size of the read-out at that dose, not a potency): 70%
Compound 4: the middle estimate sits 30 percentage points below what was measured, and the stated range ends below it.
By their numbers in this assay, from the lowest: compound 3; then compounds 2 and 1 (each within the scatter of the next); then compound 4.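

In this assay the swap of methylcarbamoyl for ethyl on this nitrogen on an aromatic ring gives a number 43 percentage points higher from compound 3 to compound 4 (beyond the scatter) and shows that the low number of compound 3 does not hold for every substituent here. Ethylamino in place of aminomethyl gives a number 21 percentage points higher from compound 2 to compound 4 (beyond the scatter), so this group also exceeds the aminomethyl compound, which the earlier steps did not show. Nothing available accounts for either rise. From the compounds shown here alone, whether a longer chain such as propyl on this nitrogen would raise the number further remains open, as does the effect of a cyclopropyl group there.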